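Sulfonyl for sulfanyl on a second fluorinated core

The compounds below may be only part of what the source reports. "The series", "measured", "known", "first", "only" and "open" are said of these compounds alone.

In an assay for binding affinity to Alpha-1D adrenergic receptor (Homo sapiens), read by radioligand binding (on this read-out lower numbers stand for stronger inhibition and higher numbers for weaker inhibition), three compounds have been measured. Compound 1 `CSc1ccc(C)cc1NCC1=NCCN1` gives 17.4 nM. Among the measured compounds shown here, compound 2 `Cc1ccc(S(C)(=O)=O)c(NCC2=NCCN2)c1` gives 4790 nM, and the step of a 280-fold higher number from compound 1 to compound 2 (2.44 log units; beyond the scatter) is the one structural change tested so far: methylsulfonyl in place of methylsulfanyl on an aromatic carbon. Compound 3 `CSc1c(F)cccc1NCC1=NCCN1` gives 302 nM, a higher number than compound 1 and a lower one than compound 2. How the core of compound 3 differs from the core of compound 1 is not broken down here.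

Compound 4 `CS(=O)(=O)c1c(F)cccc1NCC1=NCCN1` has not yet been measured. It differs from compound 3 in this way: methylsulfonyl in place of methylsulfanyl on an aromatic carbon. This is the same kind of change as that from compound 1 to compound 2, but the place is not the same: there the changed carbon is para to a methyl group, here it is ortho to a fluoro group.

Because the earlier step of a 280-fold higher number from compound 1 to compound 2 (2.44 log units; beyond the scatter) was large, a step of similar size is expected here, estimated as a 170-fold higher number from compound 3 to compound 4 (2.22 log units; beyond the scatter). Compound 4 is therefore expected to give about 50000 nM in this assay, within a range of 8000 nM to 300000 nM.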

Compound 4, inhibition constant: 3470 nM
Estimate against measurement, compound 4: 14-fold (1.16 log units) above; the measured number lies below the stated range.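

On the fluoro-bearing core, methylsulfonyl in place of methylsulfanyl again gives a weaker result in this assay, with an 11-fold higher number from compound 3 to compound 4 (1.06 log units; beyond the scatter). The direction of the step is the same on both cores, but its size does not carry over: the same change on two cores in this assay, a 280-fold higher number (2.44 log units; beyond the scatter) from compound 1 to compound 2 and an 11-fold higher number (1.06 log units; beyond the scatter) from compound 3 to compound 4, 24-fold (1.38 log units) apart, beyond the scatter of two such steps. These two pairs show that in this series the direction of the change held on both cores while a size read on one core did not predict the size on the other; they do not show what sets the size, as the core of compound 1 and the core of compound 3 differ and the changed carbon has a different neighbouring group in each pair.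

The compounds shown leave open whether the step would stay smaller with a chloro or methoxy group in place of the fluoro group. They also leave open how a methylsulfinyl group, or a longer chain on the sulfur such as ethylsulfonyl, would compare on either core.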